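Lactam swap on the core of compound 1

The source may report more compounds than this note shows. Statements on the series, on what has been measured and on what is new or still open speak of the compounds shown alone.

Values in a physicochemical assay for lipophilicity, using the shake flask method, in phosphate buffer, measured as octanol-water partition, with a stated time of 30 min, at pH 7.4; a lower number here means a more polar compound, a higher number a more lipophilic compound:
- compound 1 `O=C1c2ccccc2CN1c1cnc(NCc2c(F)ccc3c2CCO3)n2cnnc12`: 2.7
- compound 2 `Cn1nccc1-c1cnc(NCc2c(F)ccc3c2CCO3)c2cn[nH]c(=O)c12`: 2.6
- compound 3 `CC(=O)N1CCC(c2cnc(NCc3c(F)ccc4c3CCO4)c3cn[nH]c(=O)c23)CC1`: 2.9

Compound 1, at 2.7, lies within the scatter of both compound 2 and compound 3. Compound 4 `CC1(C)CC(=O)N(c2cnc(NCc3c(F)ccc4c3CCO4)n3cnnc23)C1` keeps the core of compound 1 and carries 4,4-dimethyl-2-oxopyrrolidin-1-yl on an aromatic carbon: a group of 8 heavy atoms (6 carbon, 1 nitrogen, 1 oxygen; one five-membered non-aromatic ring with 1 hetero atom) in place of a group of 10 heavy atoms (8 carbon, 1 nitrogen, 1 oxygen; one five-membered non-aromatic ring with 1 hetero atom, one six-membered aromatic ring of carbon only), on an aromatic carbon. Within the data shown here, the only measured step is a number 0.30 log units higher from compound 2 to compound 3 (within the scatter), a change of group on an aromatic carbon of another core, so it bears on this change only loosely. No step beyond the scatter is expected in this assay, with a slight lean towards a lower number. The expected step is a number 0.20 log units lower from compound 1 to compound 4 (within the scatter). For compound 4 the estimate is 2.5, expected between 2 and 3.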

Compound 4, distribution coefficient: 2
The estimate for compound 4 lay 0.50 log units above the measured number; measured number inside the range.
By their numbers in this assay, from the lowest: compound 4; then compounds 2, 1 and 3 (each within the scatter of the next).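

In this assay, the group on this aromatic carbon of the core of compound 1 can move the number beyond the scatter: with 4,4-dimethyl-2-oxopyrrolidin-1-yl entering and the six-membered aromatic ring of carbon only leaving, the result is a number 0.70 log units lower from compound 1 to compound 4 (beyond the scatter). Among these compounds, the only earlier step, on another core, stayed within the scatter. Nothing at hand accounts for the size of this step.

Open, from the compounds shown here alone, is whether an unsubstituted 2-oxopyrrolidin-1-yl, an amine or a carboxylic acid at this position would shift the number further. Also open, going by these compounds, is whether the same change gives a similar step on the core of compound 2.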